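From Trifluoromethyl to Methoxy on an Unreadable Pair

The source may report more compounds than this note shows. Statements on the series, on what has been measured and on what is new or still open speak of the compounds shown alone.

Compound 1, `O=C(Nc1cccc(C(F)(F)F)c1)C1c2ccccc2CCN1C(=O)c1ccc(Cl)cc1`: > 10000 nM
Compound 2, `O=C(Nc1cccc(C(F)(F)F)c1)C1NCCc2ccccc21`: > 10000 nM

In a functional assay on NUGC-3 cells (Homo sapiens) for inhibition, read by sulforhodamine B assay, with a stated time of 48 h (a higher number here means a weaker inhibitor of growth, a lower number a stronger inhibitor of growth), compound 1 gives > 10000 nM, which is a limit of the assay rather than a number. Compound 2 gives > 10000 nM in this assay, again a limit. The step that the two limits leave unreadable from compound 1 to compound 2 is therefore unreadable, as the limit of > 10000 nM in this assay, at which 2 of the 2 values shown sit, shows both values sitting at that limit. Compound 2 thus stands at the limit of this assay, with no number to place it more finely.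

Compound 3, `COc1cccc(NC(=O)C2NCCc3ccccc32)c1`, has not been measured. It differs from compound 2 by methoxy in place of trifluoromethyl on an aromatic carbon. For the measured compounds named here, no measured step involves this change: the only step available, between compound 1 and compound 2, concerns the amine nitrogen in the ring and could not be read. Nothing in the data therefore points to a step in either direction beyond the scatter in this assay. Compound 3 is expected to give about 20000 nM, within a range from 5000 nM to 80000 nM. The expected step that the limit leaves unreadable from compound 2 to compound 3 is accordingly small. The most likely outcome for compound 3 is again only a limit.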

Compound 3, concentration for 50% growth inhibition: > 10000 nM
Compound 3: no number, only a limit (the forecaster's own chance of this, stated with the estimate: 80%); the middle value lies beyond the limit too.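

In this assay, compound 3 gives > 10000 nM, which is a limit and not a number. For the compounds shown here, no step can therefore be read from compound 2 to compound 3, and the result adds only one more compound at the same limit: the limit of > 10000 nM in this assay, at which 3 of the 3 values shown sit. The compounds shown leave open whether methoxy in place of trifluoromethyl changes growth inhibition at all, and which change to the shared core would give a readable value.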